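Swapping a Saturated Ring for an Aromatic Ring

The source may report more compounds than this note shows. Statements on the series, on what has been measured and on what is new or still open speak of the compounds shown alone.

Compound 1 `COc1ccnc(NC[C@@H]2C[C@@H](OCC(=O)NC[C@H](NC(=O)C3(C)CCCCC3)C(=O)O)CN2C(=O)CC(C)(C)C)c1` gives 0.55 nM in an assay on a protein complex for inhibition of integrin alpha-5/beta-1 (Homo sapiens), read by ELISA (on this read-out higher numbers stand for weaker inhibition and lower numbers for stronger inhibition), the lowest of the three numbers measured here. Its closest neighbour is compound 3 `CC(C)(C)CC(=O)N1C[C@H](OCC(=O)NC[C@H](NC(=O)C2(C)CCCCC2)C(=O)O)C[C@H]1CNc1ccccn1`, which gives 1.4 nM in this assay; that pair differs only by a hydrogen in place of a methoxy on an aromatic carbon, and the change is a 2.5-fold higher number from compound 1 to compound 3 (0.41 log units; beyond the scatter). Compound 2 `O=C(CO[C@@H]1C[C@@H](CNc2ccccn2)N(C(=O)OCc2ccccc2)C1)NC[C@H](NC(=O)c1ccccc1)C(=O)O` lies far away with 155 nM in this assay, but it differs from compound 1 in more than one place, so its number cannot be tied to any single change.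

Compound 4 `COc1ccnc(NC[C@@H]2C[C@@H](OCC(=O)NC[C@H](NC(=O)c3c(C)cc(C)cc3C)C(=O)O)CN2C(=O)CC(C)(C)C)c1` is compound 1 with one alteration: 2,4,6-trimethylphenyl in place of 1-methylcyclohexyl on a carbonyl carbon. Among the compounds with values here, neither measured step touches this carbonyl carbon, so there is no direct precedent for it among the three compounds; the only step that is measured concerns a different part of the molecule. With nothing to anchor the direction, the expectation for compound 4 is a number close to that of compound 1, with a wide range to allow for a shift either way, so that compound 4 is estimated at 1.5 nM in this assay, between 0.4 nM and 6 nM, corresponding to an expected step of a 2.7-fold higher number from compound 1 to compound 4 (0.44 log units; beyond the scatter).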

Compound 4, half-maximal inhibitory concentration: 0.55 nM
For compound 4 the middle estimate is 2.7-fold (0.44 log units) above the measured one; the range from low to high includes it.
By their numbers in this assay, from the lowest: compounds 1 and 4 (each within the scatter of the next); then compound 3; then compound 2.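

In this assay, the swap on this carbonyl carbon gives no change at the digits printed from compound 1 to compound 4 (within the scatter), so at this position a saturated ring and an aromatic ring cannot be told apart by their numbers, at least on the core of compound 1. Within the data shown here, the only earlier step, a 2.5-fold higher number from compound 1 to compound 3 (0.41 log units; beyond the scatter), concerned the methoxy on the other side of the molecule, so this is the first reading of any change at this carbonyl carbon; it also shows that a group of 9 heavy atoms can take the place of one of 7 with no change beyond the scatter. Nothing available explains why the two groups give matching numbers.

Among these compounds, only two groups can be compared directly at this position, both made of carbon alone, so it remains open whether the same result would hold for a ring bearing an amine or a carboxylic acid, or for an open hexyl chain. From the compounds shown here alone, it is also open whether 2,4,6-trimethylphenyl would match 1-methylcyclohexyl on the core of compound 3, which has hydrogen in place of the methoxy.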